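Chain length and cytotoxicity in a glycosyl thiadiazole series

The compounds below may be only part of what the source reports. "The series", "measured", "known", "first", "only" and "open" are said of these compounds alone.

Measured compounds:
Compound 1, `CCCCCCCC(=O)Nc1nnc(S[C@@H]2O[C@H](CO)[C@H](O)[C@H](O)[C@H]2O)s1`, gives 60100 nM.
Compound 2, `CCCCCCCCCC(=O)Nc1nnc(S[C@@H]2O[C@H](COC(C)=O)[C@H](OC(C)=O)[C@H](OC(C)=O)[C@H]2OC(C)=O)s1`, gives 19400 nM.
Compound 3, `CCCCCCCCCCCCCCCCCC(=O)Nc1nnc(S[C@@H]2O[C@H](CO)[C@H](O)[C@H](O)[C@H]2O)s1`, gives "not active" (no number reported), with no number.

These three compounds share a sugar-linked core and differ in the length of the acyl chain on the amide and in whether the sugar hydroxyls are free or acetylated. In an ADME assay on CHO-K1 cells (Cricetulus griseus) for cytotoxicity, read by MTT assay, with a stated time of 24 h (on this read-out higher numbers stand for weaker inhibition and lower numbers for stronger inhibition), compound 2 gives 19400 nM, the lowest of the two numbers at hand; compound 1 gives 60100 nM, a higher number that lies beyond the usual scatter, and compound 3 has no number at all.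

Compound 4, `CCCCCCCCCCCCCCCC(=O)Nc1nnc(S[C@@H]2O[C@H](COC(C)=O)[C@H](OC(C)=O)[C@H](OC(C)=O)[C@H]2OC(C)=O)s1`, has not been measured. It keeps the acetylated sugar of compound 2 but carries a longer chain: hexyl in place of hydrogen on a saturated chain carbon, nine bonds along the chain from a carbonyl carbon. Since compound 3, with the longest chain, is reported as not active, the lengthening is expected to move the number upward, toward weaker inhibition, by a step beyond the scatter. For compound 4 the expected step is a 2.3-fold higher number from compound 2 to compound 4 (0.37 log units; beyond the scatter), giving an estimated 45000 nM, between 15000 nM and 150000 nM.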

Compound 4, half-maximal inhibitory concentration: 90400 nM
Compound 4: middle estimate off by 2.0-fold (0.30 log units), on the low side; low and high end bracket the measured number.
By their numbers in this assay, from the lowest: compound 2; then compounds 1 and 4 (each within the scatter of the next).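

On the acetylated sugar, hexyl in place of hydrogen on a saturated chain carbon, nine bonds along the chain from a carbonyl carbon, gives a 4.7-fold higher number from compound 2 to compound 4 (0.67 log units; beyond the scatter) in this assay, a modest step beyond the usual scatter toward weaker inhibition. Among these compounds, this is the first pair here that isolates chain length, since compound 1 and compound 3 each differ from compound 2 in both the chain and the sugar hydroxyls. No measurement at hand says why the number moves.

The compounds shown leave open whether a shorter chain on the acetylated sugar, or a chain carrying an amine or a carboxylic acid, would move the number the same way. They also leave open whether the same lengthening has a similar effect with free sugar hydroxyls, where compound 3 offers no number.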